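Halogen-to-ester swap on the arylthio group

A few compounds are considered here, and "the series" means these few. Any claim that something is new, unique, unknown or untested is made for them only; others in the source may bear on it.

Compound 1 `OC[C@H]1O[C@@H](n2cnc3c(CSc4cccc(Br)c4)ncnc32)[C@H](O)[C@@H]1O` and compound 2 `OC[C@H]1O[C@@H](n2cnc3c(CSc4cccc(I)c4)ncnc32)[C@H](O)[C@@H]1O` share the core and differ only on the aromatic ring. In an assay on isolated protein for binding affinity to Equilibrative nucleoside transporter 1 (Homo sapiens) (on this read-out higher numbers stand for weaker inhibition and lower numbers for stronger inhibition), compound 1 gives 363 nM, and compound 2 gives 245 nM, the lower of the two numbers; the step of a 1.5-fold lower number from compound 1 to compound 2 (0.17 log units; within the scatter) stays within the scatter. Compound 3 `COC(=O)c1ccc(SCc2ncnc3c2ncn3[C@@H]2O[C@H](CO)[C@@H](O)[C@H]2O)cc1` carries the change (4-(methoxycarbonyl)phenyl in place of 3-iodophenyl on a sulfur). Within the data shown here, no measured step covers an ester in place of a halogen, so the halogen step is the only guide, and little change beyond the scatter is expected, a 1.6-fold higher number from compound 2 to compound 3 (0.21 log units; within the scatter). Compound 3 is therefore estimated at 400 nM, between 120 nM and 1300 nM.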

Compound 3, half-maximal inhibitory concentration: 813 nM
For compound 3 the middle estimate is 2.0-fold (0.31 log units) below the measured one, within the range that was stated.
By their numbers in this assay, from the lowest: compounds 2 and 1 (each within the scatter of the next); then compound 3.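

In this assay this position responds to a change of group beyond the scatter: 4-(methoxycarbonyl)phenyl in place of 3-iodophenyl on the sulfur gives a 3.3-fold higher number from compound 2 to compound 3 (0.52 log units; beyond the scatter) and in place of 3-bromophenyl gives a 2.2-fold higher number from compound 1 to compound 3 (0.35 log units; beyond the scatter). The exchange of one halogen for the other had shown no such separation, and both new steps are modest. No available evidence accounts for the shift. The effect of the ester cannot be separated from that of its ring position here. As far as these compounds go, a carboxylic acid or an amine on this ring remains open.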